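The compounds below may be only part of what the source reports. "The series", "measured", "known", "first", "only" and "open" are said of these compounds alone.

Of the compounds shown here, three that share one core have been tested in a functional assay on HL-60 cells (Homo sapiens) for antiproliferative activity, with a stated time of 24 h; a lower number here means a stronger inhibitor, a higher number a weaker inhibitor. Compound 1 `Cc1ccccc1C(=O)Nc1sc2c(c1C(N)=O)CCN(C(=S)Nc1ccccc1Cl)C2` gives 20900 nM. Compound 2 `COc1ccccc1C(=O)Nc1sc2c(c1C(N)=O)CCN(C(=S)Nc1ccccc1Cl)C2` gives 20800 nM in this assay. Compound 3 `CSc1ccccc1C(=O)Nc1sc2c(c1C(N)=O)CCN(C(=S)Nc1ccccc1Cl)C2` gives 30500 nM in this assay, which is the highest of the three numbers, yet its distance from the other two stays inside the scatter: a 1.5-fold higher number from compound 1 to compound 3 (0.16 log units; within the scatter) and a 1.5-fold higher number from compound 2 to compound 3 (0.17 log units; within the scatter). The step of a 1.0-fold lower number from compound 1 to compound 2 (0.00 log units; within the scatter) is likewise small.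

Compound 4 `NC(=O)c1c(NC(=O)c2ccncn2)sc2c1CCN(C(=S)Nc1ccccc1Cl)C2` has not yet been measured. It differs from compound 3 by pyrimidin-4-yl in place of 2-(methylsulfanyl)phenyl on a carbonyl carbon. Among the compounds with values here, none of the measured steps tests an exchange of this kind; each of them only swapped one small group on the six-membered aromatic ring of carbon only that now leaves altogether, and each stayed within the scatter. They show that the three groups tried on that ring barely moved the number, but they say nothing about exchanging the whole ring for a pyrimidin-4-yl. The expectation therefore starts from compound 3, with no shown reason for a shift in either direction and a wide range to reflect the lack of a comparable step. Compound 4 is expected to give about 30000 nM in this assay, within 10000 nM to 90000 nM. This would correspond to an expected step of a 1.0-fold lower number from compound 3 to compound 4 (0.01 log units; within the scatter).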

Compound 4, half-maximal inhibitory concentration: 34600 nM
Compound 4: the middle estimate sits 1.2-fold (0.06 log units) below what was measured; measured number inside the range.
By their numbers in this assay, from the lowest: compounds 2, 1, 3 and 4 (each within the scatter of the next).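

In this assay, within the data shown here, the earlier steps changed only a small group on the six-membered aromatic ring of carbon only, whereas here the whole ring gives way to pyrimidin-4-yl, a six-membered aromatic ring with 2 hetero atoms, on the carbonyl carbon, and the number still does not separate from the others: a 1.1-fold higher number from compound 3 to compound 4 (0.05 log units; within the scatter), a 1.7-fold higher number from compound 2 to compound 4 (0.22 log units; within the scatter) and a 1.7-fold higher number from compound 1 to compound 4 (0.22 log units; within the scatter). Among these compounds, this position on the carbonyl carbon therefore accepts a far larger exchange than the earlier compounds tested, including the loss of the methylsulfanyl, methoxy or methyl group, with all four compounds remaining within the scatter of one another. Nothing measured here gives an explanation for this result.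

On these data alone, whether a carboxylic acid or an amine carried on the pyrimidin-4-yl, or a longer chain on the carbonyl carbon in place of a ring, would move the number beyond the scatter remains open. All four compounds also share the rest of the structure, so they cannot show how changes elsewhere on the shared core would affect the number.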